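Swapping the Oxan-2-yl Group for 2,3-Dihydroxypropyl

The source may hold more compounds than are shown below. What is called first, only, known or untested is meant among the compounds shown, and "the series" means these compounds.

In a functional assay on MDA-MB-231 cells (Homo sapiens) for cytotoxicity, read by MTT assay, with a stated time of 72 h (on this read-out higher numbers stand for weaker inhibition and lower numbers for stronger inhibition), compound 1 (`O=C1c2c[n+]([O-])c3ccccc3c2C(=O)c2c1c1ccccc1n2Cc1cn([C@@H]2C[C@H](O)[C@@H](CO)O2)nn1`) gives 130 nM and compound 2 (`O=C1c2c[n+]([O-])c3ccccc3c2C(=O)c2c1c1ccccc1n2Cc1cn([C@@H]2O[C@H](CO)[C@@H](O)[C@H](O)[C@H]2O)nn1`) gives 650 nM, so compound 2 holds the higher of the two numbers. Compound 3 (`O=C1c2c[n+]([O-])c3ccccc3c2C(=O)c2c1c1ccccc1n2Cc1cn(C[C@@H](O)CO)nn1`) keeps the shared core and changes the group on the aromatic nitrogen: 2,3-dihydroxypropyl in place of 3,4,5-trihydroxy-6-(hydroxymethyl)oxan-2-yl on an aromatic nitrogen. Within the data shown here, the only measured step that bears on this change is a 5.0-fold higher number from compound 1 to compound 2 (0.70 log units; beyond the scatter), a modest step at the same nitrogen. No group without a ring has been measured here, so this step is only a partial guide. Compound 1, at 130 nM, shows that a lower number than that of compound 2 is possible at this nitrogen, so a modest move downward is expected in this assay. The estimated change is a 2.2-fold lower number from compound 2 to compound 3 (0.34 log units; beyond the scatter). The expected value for compound 3 is 300 nM, with an estimated range of 100 nM to 900 nM.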

Compound 3, half-maximal inhibitory concentration: 670 nM
Beside the measured number, compound 3's estimate is 2.2-fold (0.35 log units) below it; the range from low to high includes it.
By their numbers in this assay, from the lowest: compound 1; then compounds 2 and 3 (each within the scatter of the next).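

The change of 3,4,5-trihydroxy-6-(hydroxymethyl)oxan-2-yl to 2,3-dihydroxypropyl gives a 1.0-fold higher number from compound 2 to compound 3 (0.01 log units; within the scatter) in this assay, so at this aromatic nitrogen the group with no ring and the larger ring-bearing group cannot be told apart. The other comparison, a 5.2-fold higher number from compound 1 to compound 3 (0.71 log units; beyond the scatter) in this assay, shows that the group with no ring does not reach the lower number of compound 1, which leaves 4-hydroxy-5-(hydroxymethyl)oxolan-2-yl as the only group shown here that stands apart beyond the scatter. No measurement at hand gives a reason for these results.

The compounds shown leave open whether this lower number depends on the ring of compound 1 or on its hydroxyl and hydroxymethyl groups. They also leave open how a longer chain ending in an amine or a carboxylic acid would behave at this nitrogen.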